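Ring Swap at the Shared Core: Expecting Compound 3

The compounds below may be only part of what the source reports. "The series", "measured", "known", "first", "only" and "open" are said of these compounds alone.

Of the compounds shown here, two have been measured in an assay on HeLa cells for inhibition of sphingosine-1-phosphate transporter SPNS2 (Mus musculus), read by LC-MS, tested at 2 uM; a lower number here means less inhibition, a higher number more inhibition at the concentration tested (going by the name of the read-out). Compound 1 `CCCCCCCCCCc1ccc(-c2noc(CC3CCNC3)n2)cc1` gives 44% in this assay, and compound 2 `CCCCCCCCCCc1ccc(-c2noc(C3CCNCC3)n2)cc1` gives 66%. For the measured compounds named here, the only measured step, a number 22 percentage points higher from compound 1 to compound 2 (beyond the scatter), shows that exchanging the group on this aromatic carbon moves the read-out by a modest amount. Going by the values given here, on the numbers so far compound 2 stands highest of the two, and the only other compound, compound 1, lies beyond the scatter below it.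

Compound 3 `CCCCCCCCCCc1ccc(-c2noc([C@@H]3CC[C@H](N)C3)n2)cc1` has not yet been measured. It differs from compound 2 by 3-aminocyclopentyl in place of piperidin-4-yl on an aromatic carbon. Among the compounds with values here, no measured step covers this exact change; the one step from compound 1 to compound 2 bears on it only in that it concerns the same position and shows that altering the group there can shift the read-out modestly. With no closer guide, compound 3 is expected to land near compound 2 or somewhat lower, a step of a number 11 percentage points lower from compound 2 to compound 3 (beyond the scatter). The estimate for compound 3 in this assay is 55%, with a range from 30% to 80%.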

Compound 3, a percentage reported as inhibition, at one concentration (the size of the read-out at that concentration, not a potency): 38%
For compound 3 the middle estimate is 17 percentage points above the measured one, within the range that was stated.
By their numbers in this assay, from the lowest: compounds 3 and 1 (each within the scatter of the next); then compound 2.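

Piperidin-4-yl and 3-aminocyclopentyl have the same count of heavy atoms, donors and acceptors, yet in this assay there is a number 28 percentage points lower from compound 2 to compound 3 (beyond the scatter), so at this position the atom count alone does not set the read-out; what differs is that the nitrogen sits in the six-membered ring of one group, while the five-membered ring of the other is carbon only. The comparison with the other earlier compound gives a number 6 percentage points lower from compound 1 to compound 3 (within the scatter), so (pyrrolidin-3-yl)methyl and 3-aminocyclopentyl cannot be told apart here, and among these three compounds only piperidin-4-yl stands clear of the others. Nothing available explains why piperidin-4-yl gives the highest number of the three.

The compounds shown leave open how much of the drop belongs to the ring size, to the place of the nitrogen, or to the particular arrangement of the 2 defined stereocentres in 3-aminocyclopentyl. They also leave open what a piperazin-1-yl group or an open-chain aminoethyl group would do on this same aromatic carbon of the shared core.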